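The source may hold more compounds than are shown below. What is called first, only, known or untested is meant among the compounds shown, and "the series" means these compounds.

Of the compounds shown here, three have been tested in a functional assay on BEL-7404 cells (Homo sapiens) for cytotoxicity, read by MTT assay, with a stated time of 72 h (a higher number here means a weaker inhibitor, a lower number a stronger inhibitor), and none of them gives a number. Compound 1 `COCOc1cc(/C=C/C(=O)OCC(=O)Nc2ccc(Cl)cc2)ccc1OCc1ccccc1` reads > 200000 nM as a limit of the assay. Compound 2 `O=C(COC(=O)/C=C/c1ccc(O)c(O)c1)NN1CCOCC1` reads > 200000 nM as a limit too. Compound 3 `COc1cc(/C=C/C(=O)OCC(=O)Nc2ccc(Cl)cc2)cc(OC)c1OCc1ccc(Cl)c(Cl)c1` reads > 200000 nM as a limit again. Compound 2 thus stands with the other two, and the record holds only the limit of > 200000 nM in this assay, at which 3 of the 3 values shown sit, for now. Compound 4 `COc1ccc(NC(=O)COC(=O)/C=C/c2ccc(O)c(O)c2)cc1` carries 4-methoxyphenyl in place of morpholin-4-yl on an amide-type nitrogen with 4-methoxyphenyl in place of morpholin-4-yl on an amide-type nitrogen as the counted difference. Among the measured compounds shown here, no step between measured compounds is available as a guide. In this assay the estimated step is an at least 2.0-fold lower number from compound 2 to compound 4 (0.30 log units; that floor lies within the scatter) as a modest expected strengthening, though only a limit may be reported again. Compound 4 is expected at 100000 nM with an estimated range from 25000 nM to 200000 nM overall.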

Compound 4, half-maximal inhibitory concentration: > 200000 nM
Compound 4 ended at the assay's limit; the forecaster's own chance of this, stated with the estimate: 45%; middle value at least 2.0-fold (0.30 log units) from the limit.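

Compound 2 and compound 4 both end at a limit of the assay, so no step can be read between them: the limit of > 200000 nM in this assay, at which 4 of the 4 values shown sit.

The compounds shown leave open whether 4-methoxyphenyl in place of morpholin-4-yl changes the read-out in this assay at all.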